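Moving the Amino Group Around the Benzyl Ring

This account rests on a few compounds, and the source may have more. Where it says the series, first, only, none or still open, it means among the compounds named here.

Compound 1 `COc1ccccc1Cn1cc(CCCCC[C@@H]2SC[C@@H]3NC(=O)N[C@@H]32)nn1` in an assay on isolated protein for inhibition of biotin--protein ligase (Homo sapiens), read by scintillation counting, with a stated time of 10 min (a higher number here means a weaker inhibitor, a lower number a stronger inhibitor), gives > 16000 nM, a limit of the assay rather than a number.
Compound 2 `Nc1ccccc1Cn1cc(CCCCC[C@@H]2SC[C@@H]3NC(=O)N[C@@H]32)nn1` in this assay gives > 16000 nM, again a limit rather than a number.

Compound 2 therefore stands at the edge of what this assay can resolve, with a limit only and no measured inhibition constant. For the measured compounds named here, the one change measured so far, a step that the two limits leave unreadable from compound 1 to compound 2, cannot be read for size, because both compounds sit at the same limit, (the limit of > 16000 nM in this assay, at which 2 of the 2 values shown sit).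

Compound 3 `Nc1cccc(Cn2cc(CCCCC[C@@H]3SC[C@@H]4NC(=O)N[C@@H]43)nn2)c1` differs from compound 2 in one place: 3-aminophenyl in place of 2-aminophenyl on a saturated chain carbon bound to an aromatic nitrogen. Going by the values given here, no measured step bears on a shift of the amino group around this ring, so no direction can be drawn from the data. Among the compounds with values here, since compound 2 shows only a limit, and the sole comparison is unreadable, compound 3 is expected to sit near the same limit, with the step that the limit leaves unreadable from compound 2 to compound 3 expected to be small or unreadable. The estimate for compound 3 is 20000 nM, within a range from 5000 nM to 80000 nM, and the outcome is expected most likely to be reported as a limit again.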

Compound 3, inhibition constant: > 16000 nM
Compound 3 was reported as a limit; the forecaster's own chance of this, stated with the estimate: 75%; the middle value lies beyond the limit too.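

No step among compound 1, compound 2 and compound 3 can be read for size, since all three sit at the same limit of the assay: the limit of > 16000 nM in this assay, at which 3 of the 3 values shown sit.

The compounds shown leave open whether 2-aminophenyl, 3-aminophenyl and 2-methoxyphenyl differ at all in inhibition, and how far past the limit each compound lies.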